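This account rests on a few compounds, and the source may have more. Where it says the series, first, only, none or still open, it means among the compounds named here.

Measured in a functional assay on NCI-H460 cells (Homo sapiens) for antiproliferative activity, read by CCK-8 assay, with a stated time of 72 h, tested at 8 uM; a higher number here means a stronger effect of the compound at the concentration tested, a lower number a weaker effect:
compound 1 `Cc1ccc(Nc2nc(Cl)nc3c2ncn3Cc2ccc(C(=O)Nc3ccccc3N)cc2)cc1` gives 82.5%;
compound 2 `Cc1ccc(Nc2nc(Cl)nc3c2ncn3Cc2ccc(/C=C/C(=O)Nc3ccccc3N)cc2)cc1` gives 51.3%;
compound 3 `CC(C)n1cnc2c(Nc3cccc(Cl)c3)nc(NCOCc3ccc(C(=O)Nc4ccccc4N)cc3)nc21` gives 43.2%.

Compound 2 differs from compound 1 in one place: 2-((2-aminophenyl)carbamoyl)ethenyl in place of (2-aminophenyl)carbamoyl on an aromatic carbon. This change lowered the read-out, a number 31.2 percentage points lower from compound 1 to compound 2 (beyond the scatter). Compound 3 carries a different core; how its core differs from that of compound 1 is not broken down here. Its value lies far below that of compound 1 but within the scatter of compound 2. Compound 4 `CC(C)n1cnc2c(Nc3cccc(Cl)c3)nc(NCOCc3ccc(/C=C/C(=O)Nc4ccccc4N)cc3)nc21` is not yet measured and stands to compound 3 as compound 2 stands to compound 1: 2-((2-aminophenyl)carbamoyl)ethenyl in place of (2-aminophenyl)carbamoyl on an aromatic carbon, the same change at the same kind of place. Resting on that single earlier step, compound 4 is expected to fall by about a number 26.2 percentage points lower from compound 3 to compound 4 (beyond the scatter) in this assay. The read-out has a floor, so the drop is expected somewhat smaller than the earlier one. Compound 4 is estimated at 17%, between 5% and 32% in this assay.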

Compound 4, a percentage reported as inhibition, at one concentration (the size of the read-out at that concentration, not a potency): 61.1%
The estimate for compound 4 lay 44.1 percentage points below the measured number, outside the stated range (above it).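

In this assay, 2-((2-aminophenyl)carbamoyl)ethenyl in place of (2-aminophenyl)carbamoyl gives a number 17.9 percentage points higher from compound 3 to compound 4 (beyond the scatter), a step opposite in direction to the earlier one. The effect of this change therefore does not carry from one core to the other in this series: the same change on two cores in this assay, a number 31.2 percentage points lower (beyond the scatter) from compound 1 to compound 2 and a number 17.9 percentage points higher (beyond the scatter) from compound 3 to compound 4, 49.1 percentage points apart, beyond the scatter of two such steps. These two pairs show that the outcome differs with the core at this single concentration, but they do not show which part of the cores matters or predict the outcome on a third core.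

The compounds shown leave open whether a saturated ethylene link in place of the ethenyl would follow either step. They also leave open whether a hydroxamic acid in place of the (2-aminophenyl)carbamoyl would differ with the core in the same way.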